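Trifluorophenyl for Methoxyphenyl in a Cytotoxicity Series

The source may report more compounds than this note shows. Statements on the series, on what has been measured and on what is new or still open speak of the compounds shown alone.

Measured compounds:
compound 1 `COc1ccc(/C=C/C(=O)Nc2cc(C(=O)c3cc(OC)c(OC)c(OC)c3)ccc2OC)cc1`: 11800 nM
compound 2 `COc1ccc(/C=C/C(=O)Nc2cc(C(=O)c3cc(OC)c(OC)c(OC)c3)cc(OC)c2OC)cc1`: 12500 nM

In a functional assay on ME-180 cells (Homo sapiens) for cytotoxicity, read by MTT assay, with a stated time of 72 h (on this read-out higher numbers stand for weaker inhibition and lower numbers for stronger inhibition), compound 2 gives 12500 nM, the higher of the two numbers. Within the data shown here, compound 1 gives 11800 nM, and the single step shows a 1.1-fold higher number from compound 1 to compound 2 (0.03 log units; within the scatter), a methoxy in place of hydrogen on an aromatic carbon. Compound 3 `COc1cc(C(=O)c2cc(OC)c(OC)c(OC)c2)cc(NC(=O)/C=C/c2cc(F)c(F)c(F)c2)c1OC` differs from compound 2 by 3,4,5-trifluorophenyl in place of 4-methoxyphenyl on a double-bonded chain carbon bound to a double-bonded chain carbon. No measured step touches this part of the shared core, so there is no shown basis for a shift beyond the scatter. Compound 3 is therefore expected to give 12000 nM (range 4000 nM to 40000 nM). That estimate means a step of a 1.0-fold lower number from compound 2 to compound 3 (0.02 log units; within the scatter).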

Compound 3, half-maximal inhibitory concentration: 7100 nM
The estimate for compound 3 lay 1.7-fold (0.23 log units) above the measured number; low and high end bracket the measured number.
By their numbers in this assay, from the lowest: compounds 3, 1 and 2 (each within the scatter of the next).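

In this assay, placing 3,4,5-trifluorophenyl in place of 4-methoxyphenyl on a double-bonded chain carbon bound to a double-bonded chain carbon gives a 1.8-fold lower number from compound 2 to compound 3 (0.25 log units; within the scatter) and so stays within the usual spread of repeats. Among these compounds, this is the first reading at this position, since the earlier step changed a different part of the molecule. Nothing measured here explains this small step.

As far as these compounds go, whether a phenyl ring carrying an amine or a carboxylic acid would also stay within that spread remains open. So does the effect of a longer chain in place of the ethenyl link.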